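Compound 4: amino in place of 2-hydroxyphenyl on compound 1

A few compounds are considered here, and "the series" means these few. Any claim that something is new, unique, unknown or untested is made for them only; others in the source may bear on it.

Going by the values given here, in a functional assay, read by spectrophotometry, with a stated time of 5 min (on this read-out lower numbers stand for stronger inhibition and higher numbers for weaker inhibition), compound 1 `O=c1cc(/C=N\c2ccccc2O)c2c(OCc3ccccc3)cc(OCc3ccccc3)cc2o1` gives 33100 nM, the lowest of the three numbers known. Compound 3 `Nc1ccccc1/N=C\c1cc(=O)oc2cc(OCc3ccccc3)ccc12` gives 217000 nM, and compound 2 `O=c1cc(/C=N\c2ccc(O)cc2)c2ccc(OCc3ccccc3)cc2o1` gives 525000 nM. Among the compounds with values here, the one measured step, a 2.4-fold lower number from compound 2 to compound 3 (0.38 log units; beyond the scatter), exchanges 4-hydroxyphenyl for 2-aminophenyl on the double-bonded nitrogen and so bears only loosely on the change at hand. Compound 4 `N/N=C\c1cc(=O)oc2cc(OCc3ccccc3)cc(OCc3ccccc3)c12` differs from compound 1 by amino in place of 2-hydroxyphenyl on a double-bonded nitrogen: a six-membered aromatic ring leaves and a single nitrogen enters. Within the data shown here, no measured step removes this ring, so the size of the move is uncertain, though a shift toward weaker inhibition seems more likely than a gain. Compound 4 is therefore expected to give 90000 nM, somewhere between 25000 nM and 350000 nM. The expected step is a 2.7-fold higher number from compound 1 to compound 4 (0.43 log units; beyond the scatter).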

Compound 4, half-maximal inhibitory concentration: 36500 nM
Estimate against measurement, compound 4: 2.5-fold (0.39 log units) above, within the range that was stated.
By their numbers in this assay, from the lowest: compounds 1 and 4 (each within the scatter of the next); then compound 3; then compound 2.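

The exchange in this assay gives a 1.1-fold higher number from compound 1 to compound 4 (0.04 log units; within the scatter) and so shows that the number does not depend on the 2-hydroxyphenyl at this place: a single amino on the double-bonded nitrogen serves as well. The earlier compounds shown here all carried a six-membered aromatic ring here, so they could not show that this ring can leave without a change beyond the scatter. No evidence at hand explains this result.

Going by these compounds, it remains open whether a dimethylamino group or a hydroxyl on the double-bonded nitrogen would give a similar number. On these data alone, it is also open whether amino would do the same on the core of compound 2.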